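A few compounds are considered here, and "the series" means these few. Any claim that something is new, unique, unknown or untested is made for them only; others in the source may bear on it.

Measured so far:
compound 1 `O=C(Cn1cc(CN2C(=O)C(=O)c3c(Cl)ccc(Cl)c32)nn1)OC1CCCCC1`; in a functional assay on MGC-803 cells (Homo sapiens) for inhibition, read by CCK-8 assay, with a stated time of 72 h (a higher number here means a weaker inhibitor, a lower number a stronger inhibitor), compound 1 gives 9780 nM.
compound 2 `O=C1C(=O)N(Cc2cn(CC(=O)N3CCNCC3)nn2)c2c(Cl)ccc(Cl)c21`; in this assay compound 2 gives "nd(insoluble)" (no result reported), so no result was obtained for compound 2 in this assay.

Compound 2 therefore stands nowhere on the numbers: it has no figure, and nothing can be compared against it. Compound 3 `O=C(Cn1cc(CN2C(=O)C(=O)c3c(Cl)ccc(Cl)c32)nn1)Nc1ccccc1` differs from compound 2 by anilino in place of piperazin-1-yl on a carbonyl carbon. Going by the values given here, with no step between measured compounds to lean on, and compound 1 as the only number in hand, any shift in this assay for compound 3 is expected to be small, most likely not beyond the scatter around that single value. Compound 3 is estimated at 6000 nM in this assay, within a range from 1500 nM to 25000 nM.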

Compound 3, half-maximal inhibitory concentration: 17500 nM
Compound 3: the middle estimate sits 2.9-fold (0.46 log units) below what was measured; measured number inside the range.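

In this assay, anilino in place of cyclohexyloxy on the carbonyl carbon gives a 1.8-fold higher number from compound 1 to compound 3 (0.25 log units; within the scatter), so this swap leaves the reading unchanged within normal scatter. Compound 2 has no number, so the change from piperazin-1-yl to anilino cannot be read. No measurement shown here offers an explanation for these results. Still open, as far as these compounds go, is whether a smaller amine, such as dimethylamino, would shift the number beyond the scatter on this carbonyl carbon. Also open, from the compounds shown here alone, is what a methoxy group on the anilino ring would do.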